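A few compounds are considered here, and "the series" means these few. Any claim that something is new, unique, unknown or untested is made for them only; others in the source may bear on it.

Measured so far in a functional assay on HCT-116 cells (Homo sapiens) for antiproliferative activity, read by MTT assay, with a stated time of 72 h; a lower number here means a stronger inhibitor, a higher number a weaker inhibitor:
compound 1 `C=CC(=O)Nc1nc(-c2ccccc2)cs1`: 18600 nM
compound 2 `C=CC(=O)Nc1nc(-c2ccccc2)c(C)s1`: 20100 nM
compound 3 `C=CC(=O)N(CC(=O)OC(C)(C)C)c1nc(-c2ccccc2)cs1`: 20900 nM

Compound 3 stands level with the other two compounds, as all three numbers lie within the scatter of one another in this assay. The next compound is compound 4 `C=CC(=O)N(CC(=O)N1CCOCC1)c1nc(-c2ccccc2)cs1`, which has morpholin-4-yl in place of tert-butoxy on a carbonyl carbon.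

Among the compounds with values here, no measured pair shows this exchange directly, so two steps serve as indirect guides. The first is a 1.1-fold higher number from compound 1 to compound 2 (0.03 log units; within the scatter), for methyl in place of hydrogen on an aromatic carbon. It lies at a different place and shows only that this small set is flat so far. The second, a 1.1-fold higher number from compound 1 to compound 3 (0.05 log units; within the scatter), bears more closely, since (tert-butoxycarbonyl)methyl on an amide-type nitrogen brings in the group now being altered. Both steps lie within the scatter.

With the whole side chain in compound 3 giving so small a step, a change at its end is expected to give none beyond the scatter, and no direction can be favoured with confidence. The expected step is a 1.1-fold lower number from compound 3 to compound 4 (0.04 log units; within the scatter). For compound 4 the estimate is 19000 nM, with an expected range of 8500 nM to 42000 nM.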

Compound 4, half-maximal inhibitory concentration: 14600 nM
Beside the measured number, compound 4's estimate is 1.3-fold (0.11 log units) above it, and the stated range covers the measured number.
By their numbers in this assay, from the lowest: compounds 4, 1, 2 and 3 (each within the scatter of the next).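

In this assay, morpholin-4-yl in place of tert-butoxy on a carbonyl carbon gives a 1.4-fold lower number from compound 3 to compound 4 (0.16 log units; within the scatter) and so stays within the scatter. The earlier steps shown here concerned methyl on an aromatic carbon and the whole (tert-butoxycarbonyl)methyl group on the amide-type nitrogen, whereas this step alters only the group on the carbonyl carbon and shows that a six-membered non-aromatic ring with 2 hetero atoms can replace tert-butoxy, which has no ring, without a step beyond the scatter. No measured evidence bears on this result, and the compounds shown cannot explain it.

No step shown so far lies beyond the scatter, so neither the exchange on the carbonyl carbon nor the substituent on the amide-type nitrogen has yet been tied to a real difference in this assay. Open, going by these compounds, is whether a free carboxylic acid or a simple dimethylamino group on the carbonyl carbon, or a longer chain on the amide-type nitrogen, would give a step beyond the scatter in this assay.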